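The source may report more compounds than this note shows. Statements on the series, on what has been measured and on what is new or still open speak of the compounds shown alone.

Compound 3, with the structure `CC(C)=CCC/C(C)=C/CC1Cc2c(OCCCOc3ccc(Cl)cc3)cc(=O)n(CCCO)c2CC1(C)C`, is the starting point of this step. For the measured compounds named here, in a functional assay on PANC-1 cells (Homo sapiens) for inhibition, read by MTT assay, with a stated time of 24 h, tested at 10 uM (on this read-out lower numbers stand for less inhibition and higher numbers for more inhibition at the one concentration tested (going by the name of the read-out)), compound 3 gives 25.2%, the bottom of the three numbers measured so far. Its nearest neighbour is compound 1, `CC(C)=CCC/C(C)=C/CC1Cc2c(O)cc(=O)n(CCCO)c2CC1(C)C`, which in this assay gives 28.7%; the step of a number 3.5 percentage points lower from compound 1 to compound 3 (within the scatter) lies within the scatter, so these two cannot be told apart. Compound 2, `CCOc1cc(=O)n(CCCO)c2c1CC(C/C=C(\C)CCC=C(C)C)C(C)(C)C2`, carries an ethyl on the same oxygen and in this assay gives 67.8%; the step of a number 42.6 percentage points lower from compound 2 to compound 3 (beyond the scatter) is beyond the scatter.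

Compound 4, `CC(C)=CCC/C(C)=C/CC1Cc2c(OC(=O)Nc3ccc(F)c(F)c3)cc(=O)n(CCCO)c2CC1(C)C`, is obtained from compound 3 by the change ((3,4-difluorophenyl)carbamoyl in place of 3-(4-chlorophenoxy)propyl on an oxygen on an aromatic ring). All three measured steps touch the same oxygen on the aromatic ring: the small ethyl brought a number 39.1 percentage points higher from compound 1 to compound 2 (beyond the scatter), whereas the larger aryl-bearing chain brought only a number 3.5 percentage points lower from compound 1 to compound 3 (within the scatter). Going by the values given here, no measured compound carries a carbamoyl group, so the direction of this step is uncertain. Since the entering group resembles the leaving one in size and in carrying an aromatic ring, an inhibition near that of compound 3 is expected, with a modest rise possible, a number 9.8 percentage points higher from compound 3 to compound 4 (within the scatter). Compound 4 is therefore estimated at 35%, with a range from 15% to 60%.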

Compound 4, a percentage reported as inhibition, at one concentration (the size of the read-out at that concentration, not a potency): 43.7%
Compound 4: middle estimate off by 8.7 percentage points, on the low side; low and high end bracket the measured number.
By their numbers in this assay, from the lowest: compounds 3 and 1 (each within the scatter of the next); then compound 4; then compound 2.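

In this assay, two groups of equal heavy-atom count on this oxygen on an aromatic ring now give different numbers: putting (3,4-difluorophenyl)carbamoyl in place of 3-(4-chlorophenoxy)propyl gives a clear rise (a number 18.5 percentage points higher from compound 3 to compound 4 (beyond the scatter)), so a large group bearing an aromatic ring does not by itself fix the outcome here. The carbamoyl also stands apart from plain hydrogen on that oxygen (a number 15 percentage points higher from compound 1 to compound 4 (beyond the scatter)), yet it falls short of the much smaller ethyl (a number 24.1 percentage points lower from compound 2 to compound 4 (beyond the scatter)), so among these four compounds the order does not follow the size of the group. No available measurement explains why the two large groups differ.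

The one step changes the link to the oxygen, the halogens and the ring substituents all at once, so the compounds shown cannot say which of these matters. A phenylcarbamoyl without fluorine, a 3-(3,4-difluorophenoxy)propyl chain or a small acetyl on the same oxygen would pull those parts apart, and a single tested concentration leaves potency itself open.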